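Replacing one side ring: compound 2 to compound 3

The source may report more compounds than this note shows. Statements on the series, on what has been measured and on what is new or still open speak of the compounds shown alone.

Values measured in a functional assay on HCT-116 cells (Homo sapiens) for inhibition, read by MTT assay, with a stated time of 72 h; a lower number here means a stronger inhibitor of growth, a higher number a weaker inhibitor of growth:
- compound 1 `COc1ccc(-c2nc3c(N4CCN(Cc5cc(C)on5)CC4)c(Br)cnc3[nH]2)cc1`: 540 nM
- compound 2 `COc1ccc(-c2nc3c(N4CCN(Cc5nccn5C)CC4)c(Br)cnc3[nH]2)cc1`: 1500 nM

Compound 2 has the higher of these two numbers, which makes it the weaker growth inhibitor of the pair. Compound 3 `COc1ccc(-c2nc3c(N4CCN(Cc5cncnc5)CC4)c(Br)cnc3[nH]2)cc1` keeps the shared core and differs from compound 2 only in the ring on a saturated chain carbon bound to an amine nitrogen in a ring: pyrimidin-5-yl in place of 1-methyl-1H-imidazol-2-yl on a saturated chain carbon bound to an amine nitrogen in a ring. Here pyrimidin-5-yl takes the place of 1-methyl-1H-imidazol-2-yl.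

Among the compounds with values here, only one measured step bears on this place: a 2.8-fold higher number from compound 1 to compound 2 (0.44 log units; beyond the scatter). It shows that a ring swap here can move the number in this assay by a modest amount, but it involves a different pair of rings, so it gives a rough size and no firm direction. Compound 2 at 1500 nM marks the top of the span seen so far, and compound 1 at 540 nM marks the bottom. Within the data shown here, a value inside that span is the cautious expectation, so no step clearly beyond the scatter is expected, only a slight drop. The expected change is a 1.5-fold lower number from compound 2 to compound 3 (0.18 log units; within the scatter). For compound 3 the estimated value is 1000 nM, with an expected range of 400 nM to 2500 nM.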

Compound 3, concentration for 50% growth inhibition: 400 nM
Estimate against measurement, compound 3: 2.5-fold (0.40 log units) above; measured number inside the range.
By their numbers in this assay, from the lowest: compounds 3 and 1 (each within the scatter of the next); then compound 2.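

In this assay, pyrimidin-5-yl in place of 1-methyl-1H-imidazol-2-yl gives a 3.8-fold lower number from compound 2 to compound 3 (0.57 log units; beyond the scatter), so the number at this position can shift beyond the scatter even when the leaving and entering groups have the same counts of heavy atoms, hydrogen-bond donors and hydrogen-bond acceptors. Ring size alone does not sort the three compounds: pyrimidin-5-yl in place of 5-methyl-1,2-oxazol-3-yl gives a 1.4-fold lower number from compound 1 to compound 3 (0.13 log units; within the scatter), so a six-membered ring and a five-membered ring give numbers that cannot be told apart here, and compound 2, with its own five-membered ring, is the weakest growth inhibitor of the three. No measurement on hand explains why the 1-methyl-1H-imidazol-2-yl compound stands apart.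

These three compounds all carry a ring with hetero atoms at this position, so they leave open how a plain phenyl ring, or a simple methyl group with no ring at all, would compare. They also leave open whether a pyridin-3-yl ring would match pyrimidin-5-yl, and whether the result holds in cell lines other than this one.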